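Difluorophenyl isomers on a coumarin-linked pyrazole: compound 3

The compounds below may be only part of what the source reports. "The series", "measured", "known", "first", "only" and "open" are said of these compounds alone.

compound 1, `Cc1nn(C)c(Oc2ccc(F)cc2)c1/C=N\CCCCCCOc1cc2oc(=O)cc(C)c2cc1Cl`, in a functional assay on U-87MG ATCC cells for antiproliferative activity against U-87 MG (Homo sapiens), read by MTT assay, with a stated time of 72 h (on this read-out higher numbers stand for weaker inhibition and lower numbers for stronger inhibition), gives 16700 nM.
compound 2, `Cc1nn(C)c(Oc2cccc(F)c2F)c1/C=N\CCCCCCOc1cc2oc(=O)cc(C)c2cc1Cl`, in this assay reaches only the limit > 25000 nM.

Compound 2 thus sits at the limit of > 25000 nM in this assay, at which 1 of the 2 values shown sits, so no number is known for it. Compound 3, `Cc1nn(C)c(Oc2ccc(F)c(F)c2)c1/C=N\CCCCCCOc1cc2oc(=O)cc(C)c2cc1Cl`, differs from compound 2 by 3,4-difluorophenyl in place of 2,3-difluorophenyl on an oxygen on an aromatic ring. Going by the values given here, the only measured step that bears on this is an at least 1.4-fold higher number from compound 1 to compound 2 (0.17 log units; that floor lies within the scatter), which lies within the scatter. Compound 3 is expected to stay weak, at roughly 20000 nM, between 8000 nM and 50000 nM. The expected step, an at least 1.2-fold lower number from compound 2 to compound 3 (0.09 log units; that floor lies within the scatter), is within the scatter.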

Compound 3, half-maximal inhibitory concentration: > 25000 nM
Compound 3: only a limit was reported; the forecaster's own chance of this, stated with the estimate: 45%; at least 1.2-fold (0.09 log units) between middle value and limit.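

In this assay compound 3 gives only a limit, > 25000 nM. Fluoro in place of hydrogen on an aromatic carbon gives an at least 1.4-fold higher number from compound 1 to compound 3 (0.17 log units; that floor lies within the scatter), so a second fluoro leaves no clear change here. The step between compound 2 and compound 3 cannot be read, and the two difluorophenyl isomers share one limit: the limit of > 25000 nM in this assay, at which 2 of the 3 values shown sit.

Where compound 2 and compound 3 would fall as actual numbers stays open, so the effect of the fluoro positions is unknown. Also open, on these data alone, is what methoxy or an amine in place of fluoro on the phenyl ring would give in this assay.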